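A few compounds are considered here, and "the series" means these few. Any claim that something is new, unique, unknown or untested is made for them only; others in the source may bear on it.

Measured in an ADME assay on microsomes from liver (Homo sapiens) for metabolic stability, read by LC-MS, using NADPH, tested at 1 uM (on this read-out lower numbers stand for a shorter-lived compound and higher numbers for a longer-lived compound), each value being a limit and not a number:

Compound 1 `Cc1nc2c(N)ncnc2n1[C@@H]1O[C@H](CN(C)C/C=C\CNC(=O)OC(C)C)[C@@H](O)[C@H]1O`: > 1.5 h
Compound 2 `CNc1ncnc2c1ncn2[C@@H]1O[C@H](CN(C)C/C=C\CN)[C@@H](O)[C@H]1O`: > 1.5 h
Compound 3 `CC(C)Nc1ncnc2c1ncn2[C@@H]1O[C@H](CN(C)C/C=C\CN)[C@@H](O)[C@H]1O`: > 1.5 h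

Compound 3 has no exact half-life, only the limit > 1.5 h. It shares that position with the other two compounds, so the whole data set comes down to the limit of > 1.5 h in this assay, at which 3 of the 3 values shown sit.

Compound 4 `CCOc1ncnc2c1ncn2[C@@H]1O[C@H](CN(C)C/C=C\CN)[C@@H](O)[C@H]1O` carries ethoxy in place of isopropylamino on an aromatic carbon. Among the compounds with values here, no measured step makes this exact exchange. The closest is a step that the two limits leave unreadable from compound 2 to compound 3, which puts isopropyl in place of methyl on a nitrogen on an aromatic ring, and it offers no size to carry over. No step beyond the usual scatter is therefore expected in this assay, and no direction is favoured. The expected step is a step that the limit leaves unreadable from compound 3 to compound 4.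

For compound 4 the estimated half-life is 2 h, with an expected range of 0.8 h to 5 h.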

Compound 4, half-life: > 1.5 h
Compound 4 was reported as a limit; the forecaster's own chance of this, stated with the estimate: 70%; the middle value does not contradict the limit.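

In this assay compound 4 gives > 1.5 h, a limit and not a number, and the steps to it from compound 2 and compound 3 cannot be read. The compounds shown leave open how their actual half-lives compare: the limit of > 1.5 h in this assay, at which 4 of the 4 values shown sit.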